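The compounds below may be only part of what the source reports. "The series", "measured", "known", "first", "only" and "open" are said of these compounds alone.

In a functional assay on MDA-MB-231 cells (Homo sapiens) for cytotoxicity, read by sulforhodamine B assay, with a stated time of 48 h (a lower number here means a stronger inhibitor of growth, a higher number a weaker inhibitor of growth), three compounds of one shared core have been measured. Compound 1 `Cc1ccc(-c2ccc([N+](=O)[O-])cc2)n1-c1ccc(-c2nc3ccccc3s2)cc1` gives 3900 nM. Compound 2 `Cc1ccc(-c2ccc(C)n2-c2ccc(-c3nc4ccc(F)cc4s3)cc2)cc1` gives 3140 nM, and compound 3 `COc1ccc(-c2ccc(C)n2-c2ccc(-c3nc4ccc(F)cc4s3)cc2)cc1` gives 3070 nM. The step of a 1.0-fold lower number from compound 2 to compound 3 (0.01 log units; within the scatter) changes nothing that can be told from the noise. Compound 3 has the lowest of the three numbers, but compound 2 and compound 1 both sit within the scatter of it, so no order among the three can be claimed.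

Compound 4 `Cc1ccc(-c2ccc([N+](=O)[O-])cc2)n1-c1ccc(-c2nc3ccc(F)cc3s2)cc1` differs from compound 3 by nitro in place of methoxy on an aromatic carbon. Among the measured compounds shown here, no measured step exchanges a nitro group for a methoxy group directly. For the measured compounds named here, the one step at this position, from methyl to methoxy, stayed within the scatter, and compound 1, which carries the same nitro group on a core differing at one other place, also lies within the scatter of compound 3. The expected step of a 1.1-fold higher number from compound 3 to compound 4 (0.04 log units; within the scatter) is therefore none beyond the scatter. Compound 4 is estimated at 3400 nM, with a range from 1700 nM to 6800 nM.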

Compound 4, concentration for 50% growth inhibition: 1670 nM
Estimate against measurement, compound 4: 2.0-fold (0.31 log units) above, outside the stated range (below it).
By their numbers in this assay, from the lowest: compounds 4, 3, 2 and 1 (each within the scatter of the next, the first and the last beyond it).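

In this assay, changing 4-methoxyphenyl to 4-nitrophenyl gives a 1.8-fold lower number from compound 3 to compound 4 (0.26 log units; within the scatter), and nitro in place of methyl at the same place gives a 1.9-fold lower number from compound 2 to compound 4 (0.27 log units; within the scatter), so even these two further exchanges at this position do not separate from the noise. Among the compounds shown here, the first step beyond the scatter comes from a different place: with the nitro group kept, fluoro in place of hydrogen on an aromatic carbon of the core gives a 2.3-fold lower number from compound 1 to compound 4 (0.37 log units; beyond the scatter), a modest change. Nothing available here bears on the reason for these numbers.

From the compounds shown here alone, whether fluoro in place of hydrogen gives a similar step alongside methyl or methoxy remains open. Also open, going by these compounds, is how an amine, a carboxylic acid or a longer chain would read at the position now holding the nitro group.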